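The compounds below may be only part of what the source reports. "The series", "measured", "known", "first", "only" and "open" are said of these compounds alone.

Measured in a functional assay on HCC 2998 cells (Homo sapiens) for inhibition, read by sulforhodamine B assay, with a stated time of 48 h; a lower number here means a stronger inhibitor of growth, a higher number a weaker inhibitor of growth:

compound 1 `COc1cc(C)cc(-c2nn(CC#N)cc2-c2ccc(-c3cccc(C(C)=O)c3)nc2)c1` — 2080 nM
compound 2 `Cc1cc(O)cc(-c2nn(CC#N)cc2-c2ccnc(-c3ccc(Oc4ccccc4)cc3)c2)c1` — 1910 nM
compound 3 `COc1cc(C)cc(-c2nn(CC#N)cc2-c2ccnc(-c3ccc(N(C)C)cc3)c2)c1` — 455 nM

Compound 3 stands lowest of the three numbers in this assay. The nearest is compound 2, whose number lies higher by a margin beyond the scatter, and the furthest is compound 1, higher still, also beyond the scatter. For the measured compounds named here, no pair of measured compounds differs in only one place, so no single step within the measured set can be read off.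

Compound 4 `Cc1cc(O)cc(-c2nn(CC#N)cc2-c2ccnc(-c3ccc(N(C)C)cc3)c2)c1` differs from compound 3 by hydrogen in place of methyl on an oxygen on an aromatic ring. The two measured compounds that share the hydroxy group with compound 4 or the methoxy group with compound 3 also differ elsewhere, on the other aryl ring, so the effect of this change on its own is not isolated by the data. The same methyl-to-hydrogen exchange in the measured set is accompanied by a higher number for compound 2 than for compound 3, but that comparison carries a second change, so only a modest step is expected here. The step from compound 3 to compound 4 is expected to be a 1.4-fold higher number from compound 3 to compound 4 (0.15 log units; within the scatter), a small rise at most, possibly within the scatter. Compound 4 is estimated at 650 nM, with a range of 250 nM to 1700 nM.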

Compound 4, concentration for 50% growth inhibition: 3190 nM
Estimate against measurement, compound 4: 4.9-fold (0.69 log units) below; the whole stated range lies below it.
By their numbers in this assay, from the lowest: compound 3; then compounds 2, 1 and 4 (each within the scatter of the next).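

For the compounds shown here, the methoxy to hydroxy change can now be read on its own in this assay: it gives a 7.0-fold higher number from compound 3 to compound 4 (0.85 log units; beyond the scatter), so with dimethylamino held constant on the other aryl ring, this oxygen substituent matters far more than the earlier compounds could show. With the hydroxy group held constant, dimethylamino in place of phenoxy gives a 1.7-fold higher number from compound 2 to compound 4 (0.22 log units; within the scatter), a step within the scatter, so dimethylamino does not bring the low number of compound 3 to a compound carrying the hydroxy group. Nothing in hand bears on why removing the methyl from this oxygen has so large an effect.

Going by these compounds, it remains open whether ethoxy or a longer alkoxy chain on this oxygen, or an amine in place of the oxygen, would keep the number near that of compound 3. Also open, on these data alone, is whether the methoxy to hydroxy step keeps its size when phenoxy, rather than dimethylamino, sits on the other aryl ring.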